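The source may report more compounds than this note shows. Statements on the series, on what has been measured and on what is new or still open speak of the compounds shown alone.

Measured so far in a functional assay on NB1 cells (Homo sapiens) for cytotoxicity, read by MTT assay, with a stated time of 3 days; a lower number here means a stronger inhibitor, a higher number a weaker inhibitor:
compound 1 `N#Cc1c(NN)nc(SCc2nc3ccccc3[nH]2)nc1-c1ccccc1` - 5.4 nM
compound 2 `N#Cc1c(NNC(N)=S)nc(SCc2nc3ccccc3[nH]2)nc1-c1ccccc1` - 5.81 nM
Not yet measured:
compound 3 `CN1CCN(c2nc(SCc3nc4ccccc4[nH]3)nc(-c3ccccc3)c2C#N)CC1`

Going by the values given here, compound 2, at 5.81 nM, cannot be ordered against the only other measured compound: the two values lie within the scatter of each other.

The change to compound 3 is a group of 7 heavy atoms (5 carbon, 2 nitrogen; one six-membered non-aromatic ring with 2 hetero atoms) in place of a group of 5 heavy atoms (1 carbon, 3 nitrogen, 1 sulfur; no ring), on an aromatic carbon. The 4-methylpiperazin-1-yl group sits on an aromatic carbon of the shared core, next to the ring nitrogen and ortho to a cyano group.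

Among the compounds with values here, one measured step bears on this: a 1.1-fold higher number from compound 1 to compound 2 (0.03 log units; within the scatter), a change on an amine nitrogen of the same substituent, which stayed within the scatter. That step is only a weak guide. Within the data shown here, it kept the amine nitrogen on the aromatic carbon, whereas compound 3 exchanges the whole group, and no measured compound carries a ring at this place. The data give no direction, and no shift beyond the scatter is expected, though on thin evidence.

The estimated step is a 1.2-fold higher number from compound 2 to compound 3 (0.08 log units; within the scatter). For compound 3 the expected value is 7 nM, with an estimated range from 2 nM to 28 nM.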

Compound 3, half-maximal inhibitory concentration: 2.4 nM
Compound 3: middle estimate off by 2.9-fold (0.46 log units), on the high side, within the range that was stated.
By their numbers in this assay, from the lowest: compound 3; then compounds 1 and 2 (each within the scatter of the next).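

Replacing the whole group on this aromatic carbon, ortho to a cyano group, moves the number in this assay beyond the scatter, giving a 2.4-fold lower number from compound 2 to compound 3 (0.38 log units; beyond the scatter) and a 2.3-fold lower number from compound 1 to compound 3 (0.35 log units; beyond the scatter) as modest steps, whereas the change further out on the amine nitrogen gave only a 1.1-fold higher number from compound 1 to compound 2 (0.03 log units; within the scatter) and stayed within it. Compound 3 is thus the strongest inhibitor of the three, and the 4-methylpiperazin-1-yl group shows that a six-membered non-aromatic ring is accepted at this place in this assay, with no loss relative to the two open-chain groups of compound 1 and compound 2, although this rests on a single ring-bearing compound. Nothing available explains why the number falls with this exchange.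

The compounds shown do not separate the contribution of the ring from that of its terminal methyl group, so an unsubstituted piperazine or a morpholine would bear directly on this question. On these data alone, it also remains open whether an open-chain tertiary amine such as dimethylamino at this place would match compound 3 or stay with the open-chain pair.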